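The source may hold more compounds than are shown below. What is called first, only, known or untested is meant among the compounds shown, and "the series" means these compounds.

Compound 2 `COc1cccc(OC)c1N1C(=O)CSC1c1cccc(C(=O)NCCCCc2ccccc2)c1` gives 31% in a functional assay on 143B cells (Homo sapiens) for inhibition, read by CCK-8 assay, with a stated time of 72 h, tested at 1 uM (a lower number here means less inhibition, a higher number more inhibition at the concentration tested (going by the name of the read-out)), the lowest of the two numbers measured; compound 1 `O=C(NCCCCc1ccccc1)c1cccc(C2SCC(=O)N2c2ccccc2)c1` gives 60%. Among the measured compounds shown here, the only step measured, a number 29 percentage points lower from compound 1 to compound 2 (beyond the scatter), shows that putting 2,6-dimethoxyphenyl on the ring nitrogen cost a modest amount of inhibition. Compound 3 `COc1c(F)cccc1N1C(=O)CSC1c1cccc(C(=O)NCCCCc2ccccc2)c1` differs from compound 2 by 3-fluoro-2-methoxyphenyl in place of 2,6-dimethoxyphenyl on an amide-type nitrogen in a ring. For the measured compounds named here, no measured step matches this change exactly, so the direction is uncertain; a small rise toward compound 1 is plausible but may not exceed the scatter. The expected step is a number 11 percentage points higher from compound 2 to compound 3 (beyond the scatter). Compound 3 is estimated at 42%, within 22% to 62%.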

Compound 3, a percentage reported as inhibition, at one concentration (the size of the read-out at that concentration, not a potency): 5%
Estimate against measurement, compound 3: 37 percentage points above, and the stated range ends above it.
By their numbers in this assay, from the lowest: compound 3; then compound 2; then compound 1.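

Putting 3-fluoro-2-methoxyphenyl on the ring nitrogen in place of 2,6-dimethoxyphenyl gives a number 26 percentage points lower from compound 2 to compound 3 (beyond the scatter), and putting it there in place of phenyl gives a number 55 percentage points lower from compound 1 to compound 3 (beyond the scatter). Inhibition at this position therefore depends on which groups the aromatic ring carries, not only on whether it carries any, and plain phenyl remains the best of the three. No supporting evidence explains this drop. Going by these compounds, it remains open whether a phenyl ring with a single methoxy group or a single fluorine would keep the inhibition of compound 1. On these data alone, the effect of an amine on that ring, or of cyclohexyl in its place, is also open.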